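This account rests on a few compounds, and the source may have more. Where it says the series, first, only, none or still open, it means among the compounds named here.

The measured compounds in an ADME assay on microsomes from liver (Rattus norvegicus) for metabolic stability, read by LC-MS, using NADPH, at 37 degrees C; on this read-out lower numbers stand for a shorter-lived compound and higher numbers for a longer-lived compound:

Compound 1, `Cc1cc(C)c(-c2nc(CN3CCC(C(=O)NCCCN4C[C@H](C)C[C@H](C)C4)CC3)c(C)o2)c(C)c1`, gives > 0.5 h, which is a limit of the assay and not a number.
Compound 2, `Cc1ccccc1-c1nc(CN2CCC(C(=O)NCCCN3CCC(C)(C)CC3)CC2)c(C)o1`, gives > 0.5 h, again a limit of the assay.
Compound 3, `Cc1ccccc1-c1nc(CN2CCC(C(=O)NCCCN3CC4CCCC(C4)C3)CC2)c(C)o1`, gives 0.123 h.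

Compound 1 thus stands only at a limit in this assay, namely (the limit of > 0.5 h in this assay, at which 2 of the 3 values shown sit); its true half-life is not known, only that it is not shorter than this.

Compound 4, `Cc1cc(C)cc(-c2nc(CN3CCC(C(=O)NCCCN4C[C@H](C)C[C@H](C)C4)CC3)c(C)o2)c1`, differs from compound 1 in one place: 3,5-dimethylphenyl in place of 2,4,6-trimethylphenyl on an aromatic carbon.

Going by the values given here, the only measured step, an at least 4.0-fold lower number from compound 2 to compound 3 (0.60 log units; beyond the scatter), concerns the ring on the saturated chain carbon, a part of the molecule that is the same in compound 1 and compound 4. No measured pair differs in the aryl group attached to the core, so nothing shown speaks directly to the change from compound 1 to compound 4. In this assay the step that the limit leaves unreadable from compound 1 to compound 4 is therefore expected to stay within the scatter, with a fair chance that compound 4 again reaches only the limit rather than a number. Compound 4 is estimated at 0.6 h, in the range 0.25 h to 1.5 h.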

Compound 4, half-life: < 0.5 h
Compound 4: only a limit was reported (the forecaster's own chance of this, stated with the estimate: 55%); at least 1.2-fold (0.07 log units) between middle value and limit.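

In this assay compound 4 gives < 0.5 h, which is a limit of the assay and not a number. Compound 1 gives > 0.5 h, likewise a limit of the assay and not a number. Going by these compounds alone, the earlier compounds held no pair that differed in the aryl group on the aromatic carbon of the shared core, and here the exchange of 2,4,6-trimethylphenyl for 3,5-dimethylphenyl gives a number no higher from compound 1 to compound 4 (the limit leaves the size open), so the direction of this change can be read for the first time, while its size cannot.

Whether the step lies within or beyond the usual scatter stays open, since the two compounds rest on limits on opposite sides of the same value and neither has a number: the limit of < 0.5 h in this assay, at which 1 of the 4 values shown sits. The compounds shown also leave open how a plain phenyl group or a pyridine ring would read at this place, and whether the same exchange would give the same direction with the other groups on the saturated chain carbon, such as those of compound 2 and compound 3.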